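The source may report more compounds than this note shows. Statements on the series, on what has been measured and on what is new or still open speak of the compounds shown alone.

Measured compounds in a functional assay on SMMC-7721 cells (Homo sapiens) for inhibition, read by MTT assay, with a stated time of 72 h, tested at 10 uM; a higher number here means a stronger effect of the compound at the concentration tested, a lower number a weaker effect:
compound 1, `Cc1cccc2ncnc(O/N=C(\C=C\c3ccccn3)/C=C/c3ccccc3OCc3ccc(Cl)cc3Cl)c12`: 93.9%
compound 2, `Clc1ccccc1COc1ccc(/C=C/C(/C=C/c2ccccn2)=N/Oc2ncnc3ccccc23)cc1`: 96.9%
compound 3, `Clc1ccc(COc2ccccc2/C=C/C(/C=C/c2ccccn2)=N/Oc2ncnc3ccccc23)c(Cl)c1`: 87.5%

All three numbers lie close together. The gaps from compound 2 to compound 1 and from compound 2 to compound 3 both fall within the scatter, so none of the three can be set apart from the others on this read-out.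

Compound 3 and compound 1 share a core and differ in one place: methyl in place of hydrogen on an aromatic carbon. This change gives a number 6.4 percentage points higher from compound 3 to compound 1 (within the scatter), a step that stays within the scatter.

Compound 4, `Cc1cccc2ncnc(O/N=C(/C=C/c3ccc(OCc4ccccc4Cl)cc3)\C=C\c3ccccn3)c12`, is not yet measured. It stands to compound 2 as compound 1 stands to compound 3: methyl in place of hydrogen on an aromatic carbon. The place is described in the same words in both cases, so this is the same change made on a second core. The difference between the core of compound 2 and the core of compound 3 is not broken down here.

For the measured compounds named here, the one earlier example of this change is small, because a number 6.4 percentage points higher from compound 3 to compound 1 (within the scatter) lies within the scatter. Compound 2 gives 96.9% in this assay, which leaves little room upward. The expected step is therefore a number 0.9 percentage points lower from compound 2 to compound 4 (within the scatter), essentially flat. Compound 4 is estimated at 96% in this assay, with the range expected to run from 89% to 99.5%.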

Compound 4, a percentage reported as inhibition, at one concentration (the size of the read-out at that concentration, not a potency): 84.7%
Beside the measured number, compound 4's estimate is 11.3 percentage points above it, and the stated range ends above it.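

In this assay, the change from quinazolin-4-yl to 5-methylquinazolin-4-yl gives a number 12.2 percentage points lower from compound 2 to compound 4 (beyond the scatter), so the same change does not give the same result on the two cores: the same change on two cores in this assay, a number 6.4 percentage points higher (within the scatter) from compound 3 to compound 1 and a number 12.2 percentage points lower (beyond the scatter) from compound 2 to compound 4, 18.6 percentage points apart, beyond the scatter of two such steps. In this series, the outcome of methyl in place of hydrogen on an aromatic carbon therefore cannot be assumed to transfer from one core to the other, and a step seen on one core is a poor guide to the step on a second. This rests on a single matched pair per core and a read-out at one concentration, and it does not show which part of the difference between the cores goes with the different outcome, nor how the change affects potency.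

The compounds shown leave open whether an ethyl group, a methoxy group or an amine in place of the methyl on the same aromatic carbon would also give different results on the two cores. They also leave open whether a core carrying only one of the differences between the core of compound 2 and the core of compound 3 would follow compound 1 or compound 4.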